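The source may report more compounds than this note shows. Statements on the series, on what has been measured and on what is new or still open speak of the compounds shown alone.

In a functional assay on MDA-MB-436 cells (Homo sapiens) for antiproliferative activity, read by MTT assay, with a stated time of 48 h (a higher number here means a weaker inhibitor, a lower number a stronger inhibitor), compound 3 `CN1CCN(c2ccc(-c3cc4c(N5CCN(C(=O)Nc6ccc(Cl)cc6)CC5)ncnc4s3)cc2)CC1` gives 9270 nM. Compound 1 `CCCNC(=O)N1CCN(c2ncnc3sc(-c4ccc(N5CCN(C)CC5)cc4)cc23)CC1` gives 12400 nM, and the pair shows a 1.3-fold lower number from compound 1 to compound 3 (0.13 log units; within the scatter), so the two stand level. Compound 2 `COc1ccc(NC(=O)N2CCN(c3ncnc4sc(-c5ccc(N6CCN(C)CC6)cc5)cc34)CC2)cc1` gives 30100 nM, and that pair shows a 3.2-fold lower number from compound 2 to compound 3 (0.51 log units; beyond the scatter).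

Compound 4 `CN1CCN(c2ccc(-c3cc4c(N5CCN(C(=O)Nc6ccccc6F)CC5)ncnc4s3)cc2)CC1` has 2-fluorophenyl in place of 4-chlorophenyl on an amide-type nitrogen. The three measured steps all fall on this same group. Replacing propyl with 4-methoxyphenyl gave a 2.4-fold higher number from compound 1 to compound 2 (0.39 log units; beyond the scatter), and the other two steps are given above. The changes on this nitrogen therefore span from nothing beyond the scatter to a modest shift, with compound 2 the only one apart from the others. Within the data shown here, no measured compound carries a 2-fluorophenyl, so there is no direct evidence for this group.

In this assay, no step beyond the scatter is expected, and the estimated step is a 1.2-fold higher number from compound 3 to compound 4 (0.09 log units; within the scatter). The expected value for compound 4 is 11500 nM, with an estimated range of 5500 nM to 24000 nM.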

Compound 4, half-maximal inhibitory concentration: 14300 nM
For compound 4 the middle estimate is 1.2-fold (0.09 log units) below the measured one; low and high end bracket the measured number.
By their numbers in this assay, from the lowest: compounds 3, 1 and 4 (each within the scatter of the next); then compound 2.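

In this assay, 2-fluorophenyl on the amide-type nitrogen stands level with both 4-chlorophenyl (a 1.5-fold higher number from compound 3 to compound 4 (0.19 log units; within the scatter)) and propyl (a 1.2-fold higher number from compound 1 to compound 4 (0.06 log units; within the scatter)), so this nitrogen tolerates a second halogen-bearing phenyl, and an aromatic group there offers no clear separation from the propyl. Among these compounds, compound 2 stays apart from the newly added compound as well (a 2.1-fold lower number from compound 2 to compound 4 (0.32 log units; beyond the scatter)), which leaves 4-methoxyphenyl as the only group of the four that differs beyond the scatter from more than one other. Nothing available explains that gap or the level standing of the other three.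

The step to compound 4 changes the halogen and its ring position together, so 4-fluorophenyl and 2-chlorophenyl would be needed to separate the two. As far as these compounds go, how an aminoalkyl chain or a carboxylic acid on this nitrogen would read also remains open.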